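This account rests on a few compounds, and the source may have more. Where it says the series, first, only, none or still open, it means among the compounds named here.

Of the compounds shown here, two have numbers so far in a functional assay on B16-F10 cells (Mus musculus) for inhibition, read by MTT assay, with a stated time of 72 h; a lower number here means a stronger inhibitor, a higher number a weaker inhibitor. Compound 1 (`CC1(C)CC(NC(=S)Nc2cccc(C#N)c2)c2cc(F)ccc2O1`) gives 35000 nM, and compound 2 (`CC1(C)CC(NC(=S)Nc2cccc([N+](=O)[O-])c2)c2cc(Cl)ccc2O1`) gives 6000 nM, the lower of the two numbers, with a gap beyond the scatter. Among the compounds with values here, these two compounds differ in more than one place, so no single-change step has been measured yet. Compound 3 (`CC1(C)CC(NC(=S)Nc2cccc([N+](=O)[O-])c2)c2cc(F)ccc2O1`) departs from compound 2 by fluoro in place of chloro on an aromatic carbon. Compound 3 keeps the nitro group of compound 2 and shares the fluoro with compound 1, which stands at 35000 nM, so the number is expected to move upward. The expected step is a 2.0-fold higher number from compound 2 to compound 3 (0.30 log units; within the scatter), a small rise near the edge of the scatter. For compound 3 the estimate is 12000 nM, with an expected range of 5000 nM to 30000 nM.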

Compound 3, half-maximal inhibitory concentration: 6000 nM
For compound 3 the middle estimate is 2.0-fold (0.30 log units) above the measured one; the measured number falls inside the stated range.
By their numbers in this assay, from the lowest: compounds 2 and 3 (each within the scatter of the next); then compound 1.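

In this assay, fluoro in place of chloro on an aromatic carbon gives no change at the digits printed from compound 2 to compound 3 (within the scatter), so with the nitro group held constant, this position shows no measurable preference between the two halogens. With fluoro held constant, nitro in place of cyano on an aromatic carbon gives a 5.8-fold lower number from compound 1 to compound 3 (0.77 log units; beyond the scatter), and of the two single changes, only this one lies beyond the scatter. No available data explain either step.

The compounds shown leave open whether the halogen position would respond to a larger replacement, such as a methoxy group or a trifluoromethyl group. They also leave open how an amine or a carboxylic acid would compare with the nitro group, and whether the nitro and cyano gap persists with chloro in the core.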